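The source may report more compounds than this note shows. Statements on the series, on what has been measured and on what is new or still open speak of the compounds shown alone.

In a functional assay on MCF7 cells (Homo sapiens) for antiproliferative activity, read by MTT assay, with a stated time of 72 h (on this read-out higher numbers stand for weaker inhibition and lower numbers for stronger inhibition), compound 1 (`O=C1COc2ccc(-c3cccc(NS(=O)(=O)c4ccc(F)cc4)c3)cc2N1`) gives 18300 nM. Compound 2 (`COc1ncc(-c2ccc3c(c2)N(c2ccc(F)cc2)C(=O)CO3)cc1NS(=O)(=O)c1ccc(F)cc1`) gives > 40000 nM, which is a limit of the assay. Compound 3 (`COc1cccc(N2C(=O)COc3ccc(-c4cccc(NS(=O)(=O)c5ccc(F)cc5)c4)cc32)c1`) gives > 40000 nM, also a limit, and so stands at the limit of > 40000 nM in this assay, at which 2 of the 3 values shown sit. Compound 4 (`CC(C)N1C(=O)COc2ccc(-c3cccc(NS(=O)(=O)c4ccc(F)cc4)c3)cc21`) differs from compound 3 by isopropyl in place of 3-methoxyphenyl on an amide-type nitrogen in a ring. Among the compounds with values here, the only measured step at this nitrogen is an at least 2.1-fold higher number from compound 1 to compound 3 (0.33 log units; beyond the scatter), with 3-methoxyphenyl in place of hydrogen. Partial return toward compound 1 is therefore expected in this assay, though the reading may again be only a limit. The expected step is an at least 1.3-fold lower number from compound 3 to compound 4 (0.12 log units; that floor lies within the scatter), a modest one towards lower numbers. For compound 4 the estimated value is 30000 nM, with an expected range of 14000 nM to 50000 nM.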

Compound 4, half-maximal inhibitory concentration: 26000 nM
The estimate for compound 4 lay 1.2-fold (0.06 log units) above the measured number, within the range that was stated.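

Isopropyl on the amide-type nitrogen in a ring stays level with hydrogen in this assay, with a 1.4-fold higher number from compound 1 to compound 4 (0.15 log units; within the scatter). Substitution at this nitrogen therefore need not drive the reading to the assay limit. The comparison with 3-methoxyphenyl gives an at least 1.5-fold lower number from compound 3 to compound 4 (0.18 log units; that floor lies within the scatter), but this is only a floor, as the value of compound 3 is a limit: the limit of > 40000 nM in this assay, at which 2 of the 4 values shown sit.

As far as these compounds go, it remains open whether a longer chain, an amine or a carboxylic acid on this nitrogen would move the number beyond the scatter from compound 1, and in which direction.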